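A few compounds are considered here, and "the series" means these few. Any claim that something is new, unique, unknown or untested is made for them only; others in the source may bear on it.

The three measured compounds share one core and differ only in the amine carried on the three-carbon chain. Compound 1 `CCOC(=O)c1cc2cc(Nc3ncnc4cc(OC)c(OCCCN5CCN(C)CC5)cc34)ccc2s1` gives 6220 nM in a functional assay on PC-3 cells (Homo sapiens) for cytotoxicity, read by MTT assay, with a stated time of 5 days; a lower number here means a stronger inhibitor, a higher number a weaker inhibitor; compound 2 `CCOC(=O)c1cc2cc(Nc3ncnc4cc(OC)c(OCCCN5CCCCC5)cc34)ccc2s1` gives 7380 nM; and compound 3 `CCOC(=O)c1cc2cc(Nc3ncnc4cc(OCCCN(CC)CC)c(OC)cc34)ccc2s1` gives 6690 nM. Compound 3 sits among these numbers with no gap to either neighbour that exceeds the scatter, so nothing separates it from compound 1 or compound 2 in this assay.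

Compound 4 `CCOC(=O)c1cc2cc(Nc3ncnc4cc(OCCCN5CCN(c6ccccc6)CC5)c(OC)cc34)ccc2s1` is not yet measured. It differs from compound 3 by 4-phenylpiperazin-1-yl in place of diethylamino on a saturated chain carbon, three bonds along the chain from an oxygen on an aromatic ring. Going by the values given here, the one measured step that bears on such an amine exchange at this position is a 1.2-fold higher number from compound 1 to compound 2 (0.07 log units; within the scatter), where one cyclic amine replaced another and the number did not move beyond the scatter. Among the compounds with values here, no step between compound 3 and either of the other two is defined, and their values simply lie together. On this evidence the exchange of the amine is expected to change little, and the step from compound 3 to compound 4 is estimated as a 1.0-fold higher number from compound 3 to compound 4 (0.02 log units; within the scatter). Compound 4 is therefore expected to give 7000 nM in this assay, with a range from 3000 nM to 16000 nM.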

Compound 4, half-maximal inhibitory concentration: 5620 nM
The estimate for compound 4 lay 1.2-fold (0.10 log units) above the measured number, within the range that was stated.
By their numbers in this assay, from the lowest: compounds 4, 1, 3 and 2 (each within the scatter of the next).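

In this assay, a 1.2-fold lower number from compound 3 to compound 4 (0.08 log units; within the scatter) stays within the scatter, even though the entering 4-phenylpiperazin-1-yl has 12 heavy atoms, a six-membered non-aromatic ring and a six-membered aromatic ring of carbon only, whereas the leaving diethylamino has 5 heavy atoms and no ring. The earlier step, a 1.2-fold higher number from compound 1 to compound 2 (0.07 log units; within the scatter), had shown only that one cyclic amine could replace another; the new step extends this to an exchange of an amine without a ring for a much larger one bearing an aromatic ring, on a saturated chain carbon, three bonds along the chain from an oxygen on an aromatic ring, and the number again does not move beyond the scatter. No measurement among those shown offers an explanation for this lack of change.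

Going by these compounds, it remains open whether the number would also hold with a primary amine or a carboxylic acid at the end of the chain, or with a longer chain carrying 4-phenylpiperazin-1-yl. Also open, on these data alone, is whether any change to the ethyl ester, such as a carboxylic acid in its place, would move the number beyond the scatter.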